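Ethyl in Place of Fluoro on a Pyridine Ether

This account rests on a few compounds, and the source may have more. Where it says the series, first, only, none or still open, it means among the compounds named here.

Measured compounds:
compound 1 `Cc1ccc(OC[C@@H]2CCN2)cn1` — 0.057 nM
compound 2 `Fc1cncc(OC[C@@H]2CCN2)c1` — 0.076 nM

Of the compounds shown here, two of a shared core have been measured in an assay on brain for binding affinity to Neuronal acetylcholine receptor; alpha4/beta2 (Rattus norvegicus), read by radioligand binding; on this read-out higher numbers stand for weaker inhibition and lower numbers for stronger inhibition. Compound 1 `Cc1ccc(OC[C@@H]2CCN2)cn1` gives 0.057 nM in this assay, and compound 2 `Fc1cncc(OC[C@@H]2CCN2)c1` gives 0.076 nM; the two numbers lie within the scatter of each other, so neither can be called the stronger binder. Compound 2 holds the higher of the two numbers, with compound 1 close by.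

Compound 3 `CCc1cncc(OC[C@@H]2CCN2)c1` has not yet been measured. It differs from compound 2 in one place: ethyl in place of fluoro on an aromatic carbon. For the measured compounds named here, no step between measured compounds isolates this kind of change, so the size of the step remains open. A small shift toward a higher number in this assay is expected for compound 3, with a 2.0-fold higher number from compound 2 to compound 3 (0.30 log units; within the scatter), though a result within the scatter would not surprise. The estimate for compound 3 in this assay is 0.15 nM, with a range from 0.04 nM to 0.6 nM.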

Compound 3, inhibition constant: 0.1 nM
For compound 3 the middle estimate is 1.5-fold (0.18 log units) above the measured one, within the range that was stated.
By their numbers in this assay, from the lowest: compounds 1, 2 and 3 (each within the scatter of the next).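

In this assay, ethyl in place of fluoro on an aromatic carbon, two atoms from the ring nitrogen, gives a 1.3-fold higher number from compound 2 to compound 3 (0.12 log units; within the scatter). For the compounds shown here, this is the only step here that isolates the change, and it shows that at this position the two-carbon ethyl group and the single fluoro atom cannot be told apart by their binding numbers. No measurement shown here bears on the reason for this result.

The compounds shown leave open whether binding would hold with other groups at this position, such as a longer chain, an amine or a carboxylic acid. A single step also cannot tell whether ethyl in place of fluoro would read the same way elsewhere on the shared core.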